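Methoxyphenyl Sulfonamide Tested at the Edge of Detection

The source may hold more compounds than are shown below. What is called first, only, known or untested is meant among the compounds shown, and "the series" means these compounds.

Of the compounds shown here, three built on one shared core have been measured in an assay on cells for inhibition of HSP60/HSP10 (Homo sapiens), with a stated time of 60 min; on this read-out lower numbers stand for stronger inhibition and higher numbers for weaker inhibition. Compound 1 `O=S(=O)(Nc1ccc(-c2nc3ccccc3o2)cc1)c1cccs1` gives 63000 nM in this assay. Compound 2 `O=S(=O)(Nc1ccc(-c2nc3ccccc3o2)cc1)c1ccccc1O` reaches only the limit of this assay, > 100000 nM. Compound 3 `C=Cc1ccc(S(=O)(=O)Nc2ccc(-c3nc4ccccc4o3)cc2)cc1` likewise stops at the limit, > 100000 nM. The step of an at least 1.5-fold higher number from compound 1 to compound 3 (0.20 log units; that floor lies within the scatter) and the step of an at least 1.5-fold higher number from compound 1 to compound 2 (0.20 log units; that floor lies within the scatter) both have floors within the scatter, and a step that the two limits leave unreadable from compound 2 to compound 3 cannot be read at all. Compound 3 thus stands at the ceiling of this assay, where the limit of > 100000 nM in this assay, at which 2 of the 3 values shown sit, marks the boundary.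

Compound 4 `COc1cccc(S(=O)(=O)Nc2ccc(-c3nc4ccccc4o3)cc2)c1` is not yet measured. It differs from compound 3 by 3-methoxyphenyl in place of 4-vinylphenyl on a sulfonyl sulfur. For the measured compounds named here, the only steps that bear on such a swap of the group on the sulfonyl sulfur are the three above, and none of them shows a readable change in either direction. Compound 4 is therefore expected to stay near the limit, and the step of an at least 1.1-fold lower number from compound 3 to compound 4 (0.04 log units; that floor lies within the scatter) is estimated as none beyond the scatter. The estimated value for compound 4 is 90000 nM, within 30000 nM to 300000 nM, with a real chance that this assay again reports only a limit.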

Compound 4, half-maximal inhibitory concentration: 80000 nM
Beside the measured number, compound 4's estimate is 1.1-fold (0.05 log units) above it; low and high end bracket the measured number.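

In this assay compound 4 returns a true number rather than a limit, which makes 3-methoxyphenyl the second group on the sulfonyl sulfur with a readable value, after the thiophen-2-yl of compound 1. The step of a 1.3-fold higher number from compound 1 to compound 4 (0.10 log units; within the scatter) shows that these two groups cannot be told apart in this read-out. Against the other two groups there are only floors, an at least 1.2-fold lower number from compound 3 to compound 4 (0.09 log units; that floor lies within the scatter) and an at least 1.2-fold lower number from compound 2 to compound 4 (0.09 log units; that floor lies within the scatter), and they stay floors because compound 2 and compound 3 each sit at a limit: the limit of > 100000 nM in this assay, at which 2 of the 4 values shown sit.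

From the compounds shown here alone, it remains open whether any group on the sulfonyl sulfur can move this number beyond the scatter. Nothing shown tells how an amine or a carboxylic acid carried on the phenyl ring there would read.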